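The source may report more compounds than this note shows. Statements on the series, on what has been measured and on what is new or still open speak of the compounds shown alone.

Compound 1 `COc1ccc(-c2cc(C(=O)/C=C/c3ccccc3)nc3cc(-c4ccccc4)nn23)cc1OC` gives 64100 nM in an ADME assay on HEK293 cells (Homo sapiens) for antiproliferative activity, read by MTT assay, with a stated time of 24 h; a higher number here means a weaker inhibitor, a lower number a stronger inhibitor. Compound 2 `COc1ccc(C(=O)/C=C/c2cc(-c3cc(OC)c(OC)c(OC)c3)n3nc(-c4ccccc4)cc3n2)cc1` gives 79800 nM in this assay. Compound 3 `COc1cc(-c2cc(/C=C/C(=O)c3ccc(C)c(C)c3)nc3cc(-c4ccccc4)nn23)cc(OC)c1OC` gives 72500 nM in this assay.

Compound 1 has the lowest of the three numbers, but its gaps to compound 3 and to compound 2 both lie within the scatter, so the three compounds cannot be put in order. Among the measured compounds shown here, the single step between compounds differing in one place, a 1.1-fold lower number from compound 2 to compound 3 (0.04 log units; within the scatter), concerns a 3,4-dimethylphenyl in place of 4-methoxyphenyl on a carbonyl carbon and lies within the scatter.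

Compound 4 `COc1ccc(-c2cc(/C=C/C(=O)c3ccccc3)nc3cc(-c4ccccc4)nn23)cc1OC` differs from compound 1 in one place: 2-benzoylethenyl in place of (2-phenylethenyl)carbonyl on an aromatic carbon. The two have the same atoms, joined differently, on an aromatic carbon of a six-membered aromatic ring with 2 nitrogen, part of a fused or bridged system of two rings. For the measured compounds named here, no measured step bears on this change; the one step that exists touches another place and is itself within the scatter, and all three measured numbers sit within the scatter of one another. Compound 4 is therefore expected to show a 1.0-fold higher number from compound 1 to compound 4 (0.01 log units; within the scatter), no step beyond the scatter. The estimate for compound 4 in this assay is 66000 nM, within a range of 30000 nM to 145000 nM.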

Compound 4, half-maximal inhibitory concentration: 51200 nM
Estimate against measurement, compound 4: 1.3-fold (0.11 log units) above; the range from low to high includes it.
By their numbers in this assay, from the lowest: compounds 4, 1, 3 and 2 (each within the scatter of the next).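

Exchanging (2-phenylethenyl)carbonyl for 2-benzoylethenyl on the aromatic carbon next to the ring nitrogen rearranges the same atoms and gives a 1.3-fold lower number from compound 1 to compound 4 (0.10 log units; within the scatter) in this assay. At this position, then, reversing the order of the carbonyl and the ethenyl link produces no difference that can be read in this measurement, which the earlier step, made at another place, could not show. No supporting evidence bears on this result.

From the compounds shown here alone, whether an amine or a carboxylic acid on the terminal phenyl ring, or a longer chain in place of the ethenyl link, would move the number beyond the scatter remains open. Going by these compounds, with each of the four numbers within the scatter of the next, it is also open whether any place on the shared core responds in this assay at all.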